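Closing the Open Group into a Ring

The compounds below may be only part of what the source reports. "The series", "measured", "known", "first", "only" and "open" are said of these compounds alone.

Compound 1 `C/N=C(\N)Nc1nnc(-c2ccccc2C(F)(F)F)s1` has the lowest number among the three measured compounds in a functional assay on the whole organism (Hindlimb) for inhibition, with Mus musculus as the target, with a stated time of 1 h (on this read-out higher numbers stand for an effect only at larger amounts of compound and lower numbers for an effect already at smaller amounts), giving 44 mg/kg. Compound 2 `CCCC/N=C(\N)Nc1nnc(-c2ccccc2C(F)(F)F)s1` gives 225 mg/kg, and compound 3 `COCCC/N=C(\N)Nc1nnc(-c2ccccc2C(F)(F)F)s1` gives 78 mg/kg. Two steps start from compound 1: a 5.1-fold higher number from compound 1 to compound 2 (0.71 log units; beyond the scatter) and a 1.8-fold higher number from compound 1 to compound 3 (0.25 log units; within the scatter); between the other two compounds there is a 2.9-fold lower number from compound 2 to compound 3 (0.46 log units; beyond the scatter). Compound 4 `CN(C1=NCCN1)c1nnc(-c2ccccc2C(F)(F)F)s1` differs from compound 1 in a different way: a group of 7 heavy atoms (4 carbon, 3 nitrogen; one five-membered non-aromatic ring with 2 hetero atoms) in place of a group of 5 heavy atoms (2 carbon, 3 nitrogen; no ring), on an aromatic carbon. The measured steps each add a chain to the open group and otherwise leave it unchanged; propyl raised the number modestly, whereas 2-methoxyethyl stayed within the scatter. None of them introduces a ring, so they bear on the new change only loosely, as a hint that alterations at this group have shifted the dose by no more than a modest amount. A step of a 1.8-fold higher number from compound 1 to compound 4 (0.26 log units; within the scatter) is therefore expected, toward a somewhat higher dose, with a real chance of no shift beyond the scatter. Compound 4 is expected to give about 80 mg/kg, within a range from 30 mg/kg to 220 mg/kg.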

Compound 4, dose for half-maximal effect: > 100 mg/kg
Compound 4: no number, only a limit; the forecaster's own chance of this, stated with the estimate: 10%; middle value at least 1.2-fold (0.09 log units) away from the limit.
By their numbers in this assay, from the lowest: compounds 1 and 3 (each within the scatter of the next); then compound 2.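

Closing the open group into a five-membered non-aromatic ring with 2 hetero atoms gives an at least 2.2-fold higher number from compound 1 to compound 4 (0.35 log units; beyond the scatter) in this assay. The earlier steps shown here only added a chain to the open group, whereas this one replaces the group itself on the aromatic carbon of the shared core, and it shows that this ring does not match compound 1 at this position. Compound 4 carries no number, only a limit of the assay, so the full size of its step stays unknown: the limit of > 100 mg/kg in this assay, at which 1 of the 4 values shown sits.

The compounds shown cannot tell whether closing the ring or the other differences in the new group drive this step. They also leave open how a simple amine or a six-membered ring containing two nitrogens would fare at this position.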